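This account rests on a few compounds, and the source may have more. Where it says the series, first, only, none or still open, it means among the compounds named here.

In an assay on isolated protein for binding affinity to 5-hydroxytryptamine receptor 3A (Homo sapiens) (on this read-out lower numbers stand for stronger inhibition and higher numbers for weaker inhibition), compound 1 `Clc1ccc(-c2n[nH]cc2N2CCCNCC2)cc1` gives 498 nM, and compound 2 `Fc1ccc(-c2n[nH]cc2N2CCCNCC2)cc1` gives 1810 nM; the step of a 3.6-fold higher number from compound 1 to compound 2 (0.56 log units; beyond the scatter) is the only one measured. Compound 2 thus stands at the higher of the two numbers. Compound 3 `COc1ccc(-c2n[nH]cc2N2CCCNCC2)cc1` differs from compound 2 by methoxy in place of fluoro on an aromatic carbon. Going by the values given here, no measured step bears on this exchange directly; only the step from compound 1 to compound 2 shows that the group at this position matters. Compound 3 is therefore expected to return part of that way, with a 1.8-fold lower number from compound 2 to compound 3 (0.26 log units; within the scatter), and its estimated value in this assay is 1000 nM, between 300 nM and 3500 nM.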

Compound 3, inhibition constant: 1230 nM
Compound 3: middle estimate off by 1.2-fold (0.09 log units), on the low side; the range from low to high includes it.
By their numbers in this assay, from the lowest: compound 1; then compounds 3 and 2 (each within the scatter of the next).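

The exchange of fluoro for methoxy on this aromatic carbon (a 1.5-fold lower number from compound 2 to compound 3 (0.17 log units; within the scatter)) stays within the scatter, although methoxy brings an additional heavy atom and a hydrogen-bond acceptor. The chloro compound 1 remains apart from the methoxy compound (a 2.5-fold higher number from compound 1 to compound 3 (0.39 log units; beyond the scatter)), and with its step to compound 2 also beyond the scatter, it is the strongest of the three. No available evidence accounts for this difference. Still open, from the compounds shown here alone, is whether bromo, methyl or an amine at this position would fall with chloro or with fluoro and methoxy.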